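The source may report more compounds than this note shows. Statements on the series, on what has been measured and on what is new or still open speak of the compounds shown alone.

Measured compounds:
compound 1 `Cc1n[nH]c(C(=O)O)c1Cc1ccc(C(N)=O)cc1`: 0%
compound 2 `Cc1n[nH]c(C(=O)O)c1Cc1ccc(-c2ccc(F)cc2)cc1`: 11%

In an assay on isolated protein for inhibition of 2-Hydroxyacid oxidase 2 (Homo sapiens), tested at 1 uM (on this read-out lower numbers stand for a weaker effect and higher numbers for a stronger effect at the one concentration tested), compound 1 gives 0%, while compound 2 gives 11%. Among the measured compounds shown here, compound 2 therefore stands highest of the two numbers, and the only measured step, a number 11 percentage points higher from compound 1 to compound 2 (beyond the scatter), sets it apart from compound 1 by a margin beyond the scatter. Compound 3 `Cc1n[nH]c(C(=O)O)c1Cc1ccc(-c2ccc(OC(F)(F)F)cc2)cc1` is the next compound, and it differs from compound 2 in one place: trifluoromethoxy in place of fluoro on an aromatic carbon.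

For the measured compounds named here, no measured step touches this change. Going by the values given here, the one step known, from carbamoyl to 4-fluorophenyl, alters a different part of the shared core, and nothing shows how a trifluoromethoxy behaves here. The expectation is thus a step of small size, a number 4 percentage points higher from compound 2 to compound 3 (within the scatter), likely within the scatter of this assay. On that basis compound 3 is estimated at 15%, with a range from 0% to 35%.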

Compound 3, a percentage reported as inhibition, at one concentration (the size of the read-out at that concentration, not a potency): 11%
The estimate for compound 3 lay 4 percentage points above the measured number; the range from low to high includes it.
By their numbers in this assay, from the lowest: compound 1; then compounds 2 and 3 (each within the scatter of the next).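

In this assay, placing trifluoromethoxy in place of fluoro on the six-membered aromatic ring of carbon only gives no change at the digits printed from compound 2 to compound 3 (within the scatter). The earlier step had shown only that 4-fluorophenyl in place of carbamoyl raised the number; this one shows that, at this position para to a large group, the read-out does not separate fluoro from the larger trifluoromethoxy, so the added heavy atoms and the added hydrogen-bond acceptor bring no detectable gain at the one concentration tested. No measurement at hand offers an explanation for this flat result.

What the compounds shown leave open is whether an amine, a hydroxyl or a longer alkyl chain at this same position would move the number beyond the scatter. They also leave open how the unsubstituted phenyl would compare with compound 2 and compound 3.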